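This account rests on a few compounds, and the source may have more. Where it says the series, first, only, none or still open, it means among the compounds named here.

Measured so far:
- compound 1 `Cn1nc2c(=O)n(CC3(O)CCN(Cc4ccc(-c5ccco5)cc4Cl)CC3)cnc2c1-c1ccc(CNCCO)cc1`: in an assay on isolated protein for inhibition of ubiquitin carboxyl-terminal hydrolase 7 (Homo sapiens), with stated times of 30 min and 2 h (a higher number here means a weaker inhibitor, a lower number a stronger inhibitor), compound 1 gives 8.2 nM
- compound 2 `Cn1nc2c(=O)n(CC3(O)CCN(Cc4ccc(C5CCCO5)cc4Cl)CC3)cnc2c1-c1ccc(CN)cc1`: compound 2 gives 3820 nM
- compound 3 `Cn1cc(-c2ccc(CN3CCC(O)(Cn4cnc5c(-c6ccc(CN)cc6)n(C)nc5c4=O)CC3)c(Cl)c2)cn1`: compound 3 gives 291 nM

Compound 1 has the lowest number of the three, so it is the strongest inhibitor in this set; compound 3 is the nearest to it and compound 2 the furthest, both separated from compound 1 by more than the usual scatter. Within the data shown here, the only single-place step among the measured compounds, a 13-fold lower number from compound 2 to compound 3 (1.12 log units; beyond the scatter), concerns a group on an aromatic carbon of the benzyl part, far from the side chain that is changed next, so it does not speak to the step considered here.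

Compound 4 `CCNCc1ccc(-c2c3ncn(CC4(O)CCN(Cc5ccc(-c6ccco6)cc5Cl)CC4)c(=O)c3nn2C)cc1` is compound 1 with one difference: hydrogen in place of hydroxy on a saturated chain carbon, two bonds along the chain from an amine nitrogen. No measured pair in this set alters that side chain, so nothing shown supports a shift in either direction, and the expectation is a step that stays within the scatter, a 1.3-fold higher number from compound 1 to compound 4 (0.13 log units; within the scatter). Compound 4 is therefore expected to give about 11 nM, with a range from 4 nM to 35 nM.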

Compound 4, half-maximal inhibitory concentration: 15.2 nM
Compound 4: the middle estimate sits 1.4-fold (0.14 log units) below what was measured; measured number inside the range.
By their numbers in this assay, from the lowest: compounds 1 and 4 (each within the scatter of the next); then compound 3; then compound 2.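

Among these compounds, no earlier pair altered the side chain on the amine nitrogen, so this is the first reading at this position. In this assay, going from (2-hydroxyethyl)amino to ethylamino gives a 1.9-fold higher number from compound 1 to compound 4 (0.27 log units; within the scatter), so the two compounds cannot be told apart, and the hydroxy group, with the hydrogen-bond donor and acceptor counted with it, shows no measurable contribution here. No measurement shown explains this result.

This single pair speaks only for hydroxy against hydrogen at this one carbon, with the rest of compound 1 held fixed. On these data alone, whether a methoxy group or a carboxylic acid at the end of the chain, a longer chain such as propyl, or a ring such as morpholine on the nitrogen would also leave the number within the scatter remains open.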